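The source may report more compounds than this note shows. Statements on the series, on what has been measured and on what is new or still open speak of the compounds shown alone.

Compound 1 `COc1cc(-n2ncnc2-c2ccc(C)cc2)cc(OC)c1OC` is the reference point of this small set. Going by the values given here, in a functional assay on Jurkat cells (Homo sapiens) for antiproliferative activity, read by MTT assay, with a stated time of 72 h (on this read-out higher numbers stand for weaker inhibition and lower numbers for stronger inhibition), compound 1 gives 300 nM, and that is the only outright number among the three measured compounds. Compound 2 `COc1cc(-n2ncnc2-c2cccc(F)c2)cc(OC)c1OC` carries a 3-fluorophenyl group in place of the 4-methylphenyl group of compound 1; in this assay compound 2 reaches only the limit > 10000 nM. Compound 3 `COc1cc(-n2ncnc2-c2ccc(Cl)c(Cl)c2)cc(OC)c1OC` carries a 3,4-dichlorophenyl group instead; in this assay compound 3 likewise reaches only the limit > 10000 nM. Both departures from compound 1 are thus large losses: an at least 33-fold higher number from compound 1 to compound 2 (1.52 log units; beyond the scatter) and an at least 33-fold higher number from compound 1 to compound 3 (1.52 log units; beyond the scatter). The step between the two remaining compounds, a step that the two limits leave unreadable from compound 2 to compound 3, cannot be read owing to the limit of > 10000 nM in this assay, at which 2 of the 3 values shown sit.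

Compound 4 `COc1cc(-n2ncnc2-c2ccc(OC(F)(F)F)cc2)cc(OC)c1OC` differs from compound 1 by trifluoromethoxy in place of methyl on an aromatic carbon. The two measured steps bear on it only loosely: each replaced 4-methylphenyl with a halogen-bearing ring and lost all measurable activity, whereas compound 4 keeps its substituent para to a large group. The analyst therefore expects a loss in this assay, beyond the scatter but smaller than those two steps. Compound 4 is estimated at 3000 nM, with a range from 600 nM to 15000 nM. The step this estimate implies is a 10-fold higher number from compound 1 to compound 4 (1.00 log units; beyond the scatter).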

Compound 4, half-maximal inhibitory concentration: > 10000 nM
Compound 4: no number, only a limit; the forecaster's own chance of this, stated with the estimate: 35%; middle value at least 3.3-fold (0.52 log units) away from the limit.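

Replacing methyl with trifluoromethoxy on the aromatic carbon para to a large group gives an at least 33-fold higher number from compound 1 to compound 4 (1.52 log units; beyond the scatter) in this assay. The earlier losses came with a change in where the ring was substituted, as in the 3-fluorophenyl of compound 2 and the 3,4-dichlorophenyl of compound 3, so they could not separate the place of the substituent from its identity. Compound 4 keeps the place of the methyl group of compound 1 and changes only the group there, which shows that keeping that place does not by itself keep a measurable number, and the steps among compound 2, compound 3 and compound 4 cannot be read: the limit of > 10000 nM in this assay, at which 3 of the 4 values shown sit.

Among the compounds shown, only methyl at this place gives a number, so it stays open whether a smaller group such as fluorine or chlorine, or a close relative such as ethyl or methoxy, would hold activity there. Also open, going by these compounds, is how an amine or a hydroxyl group at the same place would read in this assay.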